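This account rests on a few compounds, and the source may have more. Where it says the series, first, only, none or still open, it means among the compounds named here.

Measured in an ADME assay on Huh-7 cells (Homo sapiens) for cytotoxicity; on this read-out higher numbers stand for lower toxicity in this test and lower numbers for higher toxicity in this test:

Compound 1, `Cc1ccccc1-c1nn(-c2ccc(Cl)cc2)cc1CNCCN1CCN(C)CC1`, gives 17000 nM.
Compound 2, `Cc1ccccc1-c1nn(-c2ccc(F)c(F)c2)cc1CNCCN1CCN(C)CC1`, reaches only the assay limit of > 20000 nM.
Compound 3, `Cc1ccccc1-c1nn(-c2ccc(OC(F)(F)F)cc2)cc1CNCCN1CCN(C)CC1`, gives 17000 nM.

Compound 3 stands level with compound 1 at the digits shown: the step of no change at the digits printed from compound 1 to compound 3 (within the scatter) is within the scatter. Against compound 2 only a limit is known, so an at least 1.1-fold lower number from compound 2 to compound 3 (0.07 log units; that floor lies within the scatter) and an at least 1.1-fold higher number from compound 1 to compound 2 (0.07 log units; that floor lies within the scatter) are floors that also lie within the scatter, as noted in the limit of > 20000 nM in this assay, at which 1 of the 3 values shown sits. Across the three measured compounds the read-out has therefore not moved beyond the scatter, whatever the substituent on the aryl ring attached to the ring nitrogen.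

The next compound, compound 4, is `Cc1ccccc1-c1nn(-c2ccc(N)cc2)cc1CNCCN1CCN(C)CC1`; it differs from compound 3 in amino in place of trifluoromethoxy on an aromatic carbon. The measured steps that bear on it are the exchanges at the same aromatic carbon, no change at the digits printed from compound 1 to compound 3 (within the scatter), and on the same aryl ring, an at least 1.1-fold higher number from compound 1 to compound 2 (0.07 log units; that floor lies within the scatter) and an at least 1.1-fold lower number from compound 2 to compound 3 (0.07 log units; that floor lies within the scatter); none of them exceeded the scatter, though none introduced an amino group. For compound 4 no step beyond the scatter is therefore expected in this assay, no change at the digits printed from compound 3 to compound 4 (within the scatter), and its half-maximal cytotoxic concentration is estimated at 17000 nM, within 8000 nM to 36000 nM.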

Compound 4, half-maximal cytotoxic concentration: > 20000 nM
Compound 4 gave a limit, no number; the forecaster's own chance of this, stated with the estimate: 35%; middle value at least 1.1-fold (0.07 log units) from the limit.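

In this assay, the aromatic carbon para to a large group now also carries amino, the first group at this place shown with a hydrogen-bond donor, and the exchange for trifluoromethoxy gives an at least 1.1-fold higher number from compound 3 to compound 4 (0.07 log units; that floor lies within the scatter). The exchange for chloro at the same carbon gives an at least 1.1-fold higher number from compound 1 to compound 4 (0.07 log units; that floor lies within the scatter), so with amino, as with the earlier groups, no step at this place is shown to lie beyond the scatter, although both floors leave the true size of the steps unknown. Compound 4 now sits with compound 2 at the top of the readable range, so the step between these two cannot be read, and any ordering of the two remains unknown: the limit of > 20000 nM in this assay, at which 2 of the 4 values shown sit.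

From the compounds shown here alone, how far compound 2 and compound 4 lie past that limit remains open, and so does whether the aryl substituent has any effect on the read-out beyond the scatter. Also open, going by these compounds, is whether a carboxylic acid or a nitrile on the same aromatic carbon would give a step beyond the scatter in this assay, or whether a change elsewhere on the shared core would.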